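Aryl-to-aryl swap on the carbonyl carbon

The source may hold more compounds than are shown below. What is called first, only, known or untested is meant among the compounds shown, and "the series" means these compounds.

Compound 3 `CN(C(=O)c1ccc(Br)cc1)c1ccc2[nH]c(-c3n[nH]c4ccccc34)cc2n1` gives 4250 nM in a functional assay on A549 cells (Homo sapiens) for antiproliferative activity, read by MTT assay, with a stated time of 72 h (on this read-out higher numbers stand for weaker inhibition and lower numbers for stronger inhibition), and stands lowest of the two numbers shown. Compound 1 `CC(=O)N(C)c1ccc2[nH]c(-c3n[nH]c4ccccc34)cc2n1` reaches only the assay limit > 50000 nM. Compound 2 `CCC(=O)N(C)c1ccc2[nH]c(-c3n[nH]c4ccccc34)cc2n1` gives 15700 nM. Both an at least 3.1-fold lower number from compound 1 to compound 2 (0.50 log units; beyond the scatter) and a 3.7-fold lower number from compound 2 to compound 3 (0.57 log units; beyond the scatter) lower the number, and the largest step is an at least 11-fold lower number from compound 1 to compound 3 (1.07 log units; beyond the scatter). Compound 4 `COc1cccc(C(=O)N(C)c2ccc3[nH]c(-c4n[nH]c5ccccc45)cc3n2)c1` differs from compound 3 by 3-methoxyphenyl in place of 4-bromophenyl on a carbonyl carbon. Going by the values given here, the measured steps bear on this only indirectly: each replaces an alkyl group on the carbonyl carbon, whereas here one aryl group replaces another, and no step between two aryl groups has been measured. A step of about a 1.3-fold higher number from compound 3 to compound 4 (0.11 log units; within the scatter) is therefore expected, not beyond the scatter. Compound 4 is estimated at 5500 nM, range 1500 nM to 20000 nM.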

Compound 4, half-maximal inhibitory concentration: 14900 nM
Compound 4: middle estimate off by 2.7-fold (0.43 log units), on the low side, and the stated range covers the measured number.
By their numbers in this assay, from the lowest: compound 3; then compounds 4 and 2 (each within the scatter of the next). At a limit, above all of these: compound 1.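

Aryl groups on this carbonyl carbon are not interchangeable in this assay: 3-methoxyphenyl in place of 4-bromophenyl gives a 3.5-fold higher number from compound 3 to compound 4 (0.54 log units; beyond the scatter). An aryl group here does not by itself give a lower number than an alkyl group, as 3-methoxyphenyl in place of ethyl gives only a 1.1-fold lower number from compound 2 to compound 4 (0.02 log units; within the scatter). Against methyl the change gives an at least 3.3-fold lower number from compound 1 to compound 4 (0.52 log units; beyond the scatter), but this step starts from a limit: the limit of > 50000 nM in this assay, at which 1 of the 4 values shown sits.

Still open, on these data alone, is how 3-bromophenyl and 4-methoxyphenyl would read on this carbonyl carbon, which would separate the substituent from where it sits. Also open, as far as these compounds go, is how an amine or a carboxylic acid on the phenyl ring would read.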